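The source may hold more compounds than are shown below. What is called first, only, known or untested is meant among the compounds shown, and "the series" means these compounds.

Measured so far:
Compound 1, `COc1cc2c(Nc3nc4ccc(C(=O)Nc5c(C)cc(C)cc5C)cc4s3)ncnc2cc1OCCCN1CCCCC1`, in a functional assay on NCI-H661 cells (Homo sapiens) for cytotoxicity, read by WST assay, with a stated time of 72 h (on this read-out higher numbers stand for weaker inhibition and lower numbers for stronger inhibition), gives 10000 nM.
Compound 2, `COc1cc2c(Nc3nc4ccc(C(=O)Nc5c(C)cc(C)cc5C)cc4s3)ncnc2cc1OCCCN1CCCCC1C`, in this assay gives 8800 nM.

On these two numbers compound 2 stands lowest, and its nearest neighbour is compound 1, with the step of a 1.1-fold lower number from compound 1 to compound 2 (0.06 log units; within the scatter) lying within the scatter, so the two compounds cannot be ranked against each other.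

Compound 3, `CCN(CC)CCCOc1cc2ncnc(Nc3nc4ccc(C(=O)Nc5c(C)cc(C)cc5C)cc4s3)c2cc1OC`, has not yet been measured in this assay. It differs from compound 2 in one place: diethylamino in place of 2-methylpiperidin-1-yl on a saturated chain carbon, three bonds along the chain from an oxygen on an aromatic ring. For the measured compounds named here, the only measured step, a 1.1-fold lower number from compound 1 to compound 2 (0.06 log units; within the scatter), touches the same chain end but is a different kind of change, and it produced nothing beyond the scatter. Going by the values given here, there is no measured step of the present kind, so the expectation rests on the closeness of the two measured values alone. Compound 3 is therefore expected to sit near compound 2, with a step of a 1.0-fold higher number from compound 2 to compound 3 (0.01 log units; within the scatter), and an estimated value of 9000 nM, within a range from 4000 nM to 20000 nM.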

Compound 3, half-maximal inhibitory concentration: 7300 nM
Compound 3: middle estimate off by 1.2-fold (0.09 log units), on the high side; measured number inside the range.
By their numbers in this assay, from the lowest: compounds 3, 2 and 1 (each within the scatter of the next).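

Replacing 2-methylpiperidin-1-yl with diethylamino on the propyl chain gives a 1.2-fold lower number from compound 2 to compound 3 (0.08 log units; within the scatter) and replacing piperidin-1-yl with diethylamino gives a 1.4-fold lower number from compound 1 to compound 3 (0.14 log units; within the scatter) in this assay and both steps lie within the scatter. The earlier pair tested only a methyl on the ring, whereas these steps show that a group with no ring can take the ring's place at this chain end with no difference that can be read, so the three compounds cannot be ranked. Nothing measured here bears on why these numbers stay so close.

On these data alone, whether any group in this place can move the number beyond the scatter remains open. Morpholin-4-yl, a carboxylic acid or a shorter chain carrying the same diethylamino group would test this, as all three compounds shown keep a tertiary amine on a propyl chain.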